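This account rests on a few compounds, and the source may have more. Where it says the series, first, only, none or still open, it means among the compounds named here.

Compound 1, `CCOC(=O)c1sc(-c2ccccc2)nc1N1CCC(NCc2ccc(OCc3ccccc3)cc2)CC1`, gives 18.4%.
Compound 2, `CCOC(=O)c1sc(-c2ccccn2)nc1N1CCC(NCc2ccc(F)cc2)CC1`, gives 12.6%.

Both numbers come from an ADME assay on RAW264.7 cells (Mus musculus) for cytotoxicity, read by MTT assay, with a stated time of 72 h, tested at 50 uM; on this read-out lower numbers stand for less inhibition and higher numbers for more inhibition at the one concentration tested (going by the name of the read-out). Compound 2 has the lowest of the two numbers shown, but the number of compound 1 differs from it by an amount that lies within the usual scatter of such measurements, so the two compounds cannot be told apart on this read-out. Going by the values given here, no pair of compounds that differ in only one place has been measured, so there is no measured step to lean on.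

The next compound, compound 3, `CCOC(=O)c1sc(-c2ccccn2)nc1N1CCC(NCc2ccc(OCc3ccccc3)cc2)CC1`, differs from compound 2 in one place: benzyloxy in place of fluoro on an aromatic carbon. Compound 1 carries the same benzyloxy group, and its number lies within the scatter of compound 2, which suggests that compound 3 may land near both of them. The step that is expected, a number 3.4 percentage points higher from compound 2 to compound 3 (within the scatter), is small, with no clear direction, and not beyond the scatter. Compound 3 is therefore estimated to give 16%, with a range from 4% to 30%.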

Compound 3, a percentage reported as inhibition, at one concentration (the size of the read-out at that concentration, not a potency): 12.8%
Compound 3: middle estimate off by 3.2 percentage points, on the high side, and the stated range covers the measured number.
By their numbers in this assay, from the lowest: compounds 2, 3 and 1 (each within the scatter of the next).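

Going by these compounds alone, compound 3 provides the first one-place comparisons in this assay: benzyloxy in place of fluoro, on an aromatic carbon para to a large group, gives a number 0.2 percentage points higher from compound 2 to compound 3 (within the scatter) and shows that, in these compounds, this much larger group with its own aromatic ring produces no difference that this read-out can distinguish. The second comparison, pyridin-2-yl in place of phenyl on an aromatic carbon, gives a number 5.6 percentage points lower from compound 1 to compound 3 (within the scatter) and so shows that swapping this ring, at a different place in the molecule, also leaves the compounds indistinguishable at the one concentration tested. Nothing measured here offers an explanation for either result.

Still open, on these data alone, is whether a group of another kind at the position para to the large group, such as an amine or a carboxylic acid, would move the number beyond the usual scatter. Also open, as far as these compounds go, is whether the same two changes would remain as hard to detect on a different core, since each has been seen only once here.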